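Allyl to methoxycarbonyl on the shared core

The compounds below may be only part of what the source reports. "The series", "measured", "known", "first", "only" and "open" are said of these compounds alone.

In a functional assay on MCF7 cells (Homo sapiens) for inhibition, read by radiometric assay and XTT assay (a lower number here means a stronger inhibitor, a higher number a weaker inhibitor), compound 1 `CCCCCCCC[C@@]1(C)SC(O)=C(C)C1=O` gives 48 ug/mL. Compound 2 `C=CCC1=C(O)S[C@](C)(CCCCCCCC)C1=O` gives 44.4 ug/mL, and the gap between these two is small: a 1.1-fold lower number from compound 1 to compound 2 (0.03 log units; within the scatter). Compound 3 `C=CCOC1=CC(=O)S[C@]1(C)CCCCCCCC` gives 14.5 ug/mL, a lower number than either of the other two, so compound 2 stands with compound 1 at the upper end of the three values.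

The next structure is compound 4 `CCCCCCCC[C@@]1(C)SC(O)=C(C(=O)OC)C1=O`, which carries methoxycarbonyl in place of allyl on a double-bonded ring carbon. For the measured compounds named here, only one measured step bears on this place, a 1.1-fold lower number from compound 1 to compound 2 (0.03 log units; within the scatter), and it stays within the scatter. Going by the values given here, that step is a different exchange, and no measured compound carries methoxycarbonyl, so it is a weak guide. No step beyond the scatter is expected in this assay, in either direction, starting from compound 2 at 44.4 ug/mL. The estimated step is a 1.1-fold lower number from compound 2 to compound 4 (0.05 log units; within the scatter). For compound 4 the estimated value is 40 ug/mL. The expected range for compound 4 runs from 15 ug/mL to 100 ug/mL.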

Compound 4, half-maximal inhibitory concentration: 47.2 ug/mL
For compound 4 the middle estimate is 1.2-fold (0.07 log units) below the measured one; the measured number falls inside the stated range.
By their numbers in this assay, from the lowest: compound 3; then compounds 2, 4 and 1 (each within the scatter of the next).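

Working notes on the double-bonded ring carbon next to the ring atom that bears a hydroxy group: in this assay, methoxycarbonyl in place of allyl gives a 1.1-fold higher number from compound 2 to compound 4 (0.03 log units; within the scatter) and methoxycarbonyl in place of methyl gives a 1.0-fold lower number from compound 1 to compound 4 (0.01 log units; within the scatter) on the shared core. With allyl, which has no hydrogen-bond acceptors, and methoxycarbonyl, which has them, this carbon has now carried three different groups with no step beyond the scatter among compounds 1, 2 and 4. No supporting data are available to explain this flat result.

On these data alone, whether an amine or a carboxylic acid on this carbon would give a step beyond the scatter remains open. Also open, as far as these compounds go, is how a longer chain in place of the group of 8 heavy atoms would read in this assay on this core.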